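From oxolan-3-yl to 4-hydroxybutyl at the assay limit

This account rests on a few compounds, and the source may have more. Where it says the series, first, only, none or still open, it means among the compounds named here.

Compound 1 (`COc1cc2cc(C#N)ccc2c(OC)c1Oc1cc(NCC(C)C)nc(Nc2ccc(C#N)cc2)n1`), compound 2 (`COc1cc2cc(C#N)ccc2c(OC)c1Oc1cc(NC(C)(C)C)nc(Nc2ccc(C#N)cc2)n1`) and compound 3 (`COc1cc2cc(C#N)ccc2c(OC)c1Oc1cc(NC2CCOC2)nc(Nc2ccc(C#N)cc2)n1`) share a core and differ only in the group on a nitrogen on an aromatic ring. In an ADME assay on MT4 cells (Homo sapiens) for cytotoxicity, read by MTT assay, with a stated time of 5 days (on this read-out lower numbers stand for higher toxicity in this test and higher numbers for lower toxicity in this test), compound 1 gives > 125000 nM, which is a limit. Compound 2 gives > 125000 nM, also a limit. Compound 3 gives > 125000 nM, again a limit, so it has no number of its own. The set as a whole shows (the limit of > 125000 nM in this assay, at which 3 of the 3 values shown sit).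

Compound 4 (`COc1cc2cc(C#N)ccc2c(OC)c1Oc1cc(NCCCCO)nc(Nc2ccc(C#N)cc2)n1`) has not yet been measured in this assay. It carries 4-hydroxybutyl in place of oxolan-3-yl on a nitrogen on an aromatic ring.

Among the measured compounds shown here, three measured steps bear on this change, all at the same place: a step that the two limits leave unreadable from compound 1 to compound 2, a step that the two limits leave unreadable from compound 1 to compound 3 and a step that the two limits leave unreadable from compound 2 to compound 3. None of them gives a size to carry over, and none produced a number. The expectation is therefore that compound 4 will most likely stay at the limit, and that any number that does appear will lie toward lower values. The expected step is an at least 1.2-fold lower number from compound 3 to compound 4 (0.09 log units; that floor lies within the scatter). For compound 4 the estimate is 100000 nM, with an expected range of 35000 nM to 125000 nM.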

Compound 4, half-maximal cytotoxic concentration: 39100 nM
For compound 4 the middle estimate is 2.6-fold (0.41 log units) above the measured one, within the range that was stated.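

In this assay, among the compounds shown here, compound 4 is the first at this position to give a number rather than a limit, and the change shows an at least 3.1-fold lower number from compound 3 to compound 4 (0.50 log units; beyond the scatter); measured against the other two groups, the result is an at least 3.1-fold lower number from compound 2 to compound 4 (0.50 log units; beyond the scatter) and an at least 3.1-fold lower number from compound 1 to compound 4 (0.50 log units; beyond the scatter). Oxolan-3-yl and 4-hydroxybutyl both have 5 heavy atoms, so the step does not go with a change in that count; it goes with the loss of the ring and the entry of 1 hydrogen-bond donor. All three steps are floors and not sizes, and the steps among compounds 1, 2 and 3 cannot be read, because the other three compounds remain at the same limit: the limit of > 125000 nM in this assay, at which 3 of the 4 values shown sit.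

Compound 4 opens the ring and brings in the hydroxyl group in a single change, so the compounds shown do not tell which of the two goes with the lower number. A plain butyl chain, a 4-methoxybutyl group, a 4-aminobutyl group or a shorter 2-hydroxyethyl chain on the same nitrogen would bear on that question, and so would a hydroxyl group placed on a ring.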